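Swapping Cyclohexyl for 3-Fluorobenzyl on the Ring Amide Nitrogen

The source may hold more compounds than are shown below. What is called first, only, known or untested is meant among the compounds shown, and "the series" means these compounds.

Compound 1 `CS(=O)(=O)Nc1ccc2c(c1)S(=O)(=O)N=C(C1=C(O)C3CCCC3N(C3CCCCC3)C1=O)N2` was examined in an ADME assay on Huh-7 cells (Homo sapiens) for cytotoxicity, with a stated time of 72 h; on this read-out lower numbers stand for higher toxicity in this test and higher numbers for lower toxicity in this test. In this assay compound 1 gives > 10000 nM, which is a limit of the assay rather than a number. Compound 2 `CC(C)(C)CCN1C(=O)C(C2=NS(=O)(=O)c3cc(NS(C)(=O)=O)ccc3N2)=C(O)C2CCCCCC21` comes from the same series. In this assay compound 2 gives > 10000 nM, again only a limit. Going by the values given here, compound 1 therefore stands at the limit of > 10000 nM in this assay, at which 2 of the 2 values shown sit, and no measured step between two compounds that differ in one place exists in this set. Compound 3 `CS(=O)(=O)Nc1ccc2c(c1)S(=O)(=O)N=C(C1=C(O)C3CCCC3N(Cc3cccc(F)c3)C1=O)N2` has not yet been measured in this assay. It differs from compound 1 by 3-fluorobenzyl in place of cyclohexyl on an amide-type nitrogen in a ring. Since both known values sit at the limit, no change beyond the scatter is expected, and the expected step that the limit leaves unreadable from compound 1 to compound 3 is small. In this assay compound 3 is expected to give 15000 nM, in a range from 7000 nM to 40000 nM.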

Compound 3, half-maximal cytotoxic concentration: > 33000 nM
Compound 3: a limit, no number; the forecaster's own chance of this, stated with the estimate: 75%; at least 2.2-fold (0.34 log units) between middle value and limit.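

Going by these compounds alone, the values of compound 1 and compound 3 in this assay are both limits of the assay, and no step between them can be read. The compounds shown leave open whether 3-fluorobenzyl in place of cyclohexyl on the amide-type nitrogen in a ring changes this read-out at all.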